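Swapping the anilide ring on a thiazolyl chalcone scaffold

This account rests on a few compounds, and the source may have more. Where it says the series, first, only, none or still open, it means among the compounds named here.

Measured so far:
compound 1, `Cc1nc(Nc2cccc(Cl)c2)sc1C(=O)/C=C/c1ccc(Cl)cc1`, > 25000 nM
compound 2, `COc1cccc(/C=C/C(=O)c2sc(Nc3ccccc3C)nc2C)c1`, > 25000 nM

Both compounds were tested in a functional assay on NCI-H460 cells (Homo sapiens) for cytotoxicity, read by MTT assay; a lower number here means a stronger inhibitor, a higher number a weaker inhibitor. Compound 1 returns only a limit of the assay, > 25000 nM. Compound 2 likewise returns only a limit, > 25000 nM. Among the measured compounds shown here, compound 2 therefore stands at the limit, and the one further value shown sits there too; both of the values shown fall at the limit of > 25000 nM in this assay, at which 2 of the 2 values shown sit, so no potency ranking between the two can be drawn.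

Compound 3, `COc1cccc(/C=C/C(=O)c2sc(Nc3cccc(Cl)c3)nc2C)c1`, has not yet been measured in this assay. It differs from compound 2 in one place: 3-chlorophenyl in place of 2-methylphenyl on a nitrogen on an aromatic ring. For the measured compounds named here, no measured step covers that change, so no direction can be read from the two values shown. Since compound 1 carries the same (3-chlorophenyl)amino group and gives only a limit, the expected step from compound 2 to compound 3 is a step that the limit leaves unreadable from compound 2 to compound 3, that is, none beyond the scatter. Compound 3 is accordingly estimated at 30000 nM, within the range 10000 nM to 100000 nM, most likely reported again as a limit.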

Compound 3, half-maximal inhibitory concentration: > 25000 nM
Compound 3: no number, only a limit (the forecaster's own chance of this, stated with the estimate: 80%); the middle value lies beyond the limit too.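

In this assay compound 3 gives > 25000 nM, which is a limit of the assay. No step can be read from compound 2 to compound 3 or from compound 1 to compound 3, because all three compounds stop at the same limit: the limit of > 25000 nM in this assay, at which 3 of the 3 values shown sit. The compounds shown leave open whether any change on the shared core would give a measurable value.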